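The source may report more compounds than this note shows. Statements on the series, on what has been measured and on what is new or still open speak of the compounds shown alone.

Measured in a functional assay on NCI-H522 cells (Homo sapiens) for cytotoxicity, with a stated time of 3 days; a higher number here means a weaker inhibitor, a lower number a stronger inhibitor:
Compound 1, `C#Cc1nc(/C=C/C(=O)Nc2ccc(Cl)cc2)cs1`, gives 370 nM.
Compound 3, `C#Cc1nc(C(=O)N2CCN(c3ccc(Cl)cc3)CC2)cs1`, gives 28 nM.
Compound 2, `C#CCNC(=O)c1csc(Br)n1`, gives only a limit of this assay, > 40000 nM.

Compound 3 stands at the lowest of the two numbers given; the nearest, compound 1, sits at a higher number, a gap beyond the usual scatter. The value of compound 2 is a limit and not a number, (the limit of > 40000 nM in this assay, at which 1 of the 3 values shown sits). Compound 4, `C#Cc1nc(C(=O)N2CCN(CC)CC2)cs1`, differs from compound 3 in one place: ethyl in place of 4-chlorophenyl on an amine nitrogen in a ring. Within the data shown here, no step between measured compounds is given, so the size of this change is not known from the data. With the 4-chlorophenyl gone, the step of a 54-fold higher number from compound 3 to compound 4 (1.73 log units; beyond the scatter) is expected to be large and to run toward a higher number, beyond the scatter. Compound 4 is estimated at 1500 nM, with a range from 200 nM to 15000 nM.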

Compound 4, half-maximal inhibitory concentration: > 1000 nM
Compound 4: no number, only a limit; the forecaster's own chance of this, stated with the estimate: 15%; the middle value does not contradict the limit.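

In this assay, among these compounds, ethyl in place of 4-chlorophenyl on this ring nitrogen gives the first readable step, and it is large: an at least 35-fold higher number from compound 3 to compound 4 (1.55 log units; beyond the scatter). The low number of compound 3 therefore depends on what this nitrogen carries, and ethyl does not keep it. The value of compound 4 is a limit and not a number, so the full size of the step stays unknown: the limit of > 1000 nM in this assay, at which 1 of the 4 values shown sits.

The compounds shown leave open whether the ring or the chlorine counts here. An unsubstituted phenyl, a benzyl or a longer alkyl chain on this nitrogen could separate these.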